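Trimming the Amino Group of Compound 2

The compounds below may be only part of what the source reports. "The series", "measured", "known", "first", "only" and "open" are said of these compounds alone.

In a functional assay on MDA-MB-231 cells (Homo sapiens) for antiproliferative activity, with a stated time of 48 h (on this read-out lower numbers stand for stronger inhibition and higher numbers for weaker inhibition), compound 1 `CCN(CC)c1ccc(-c2ccc(C#N)cc2)nn1` gives > 25000 nM, which is a limit of the assay and not a number. Among the compounds with values here, compound 2 `CCOC(=O)c1ccc(-c2ccc(N(CC)CC)nn2)cc1` gives 1500 nM, the only true number so far. Within the data shown here, the one measured step, an at least 16-fold lower number from compound 1 to compound 2 (1.22 log units; beyond the scatter), is large and goes with ethoxycarbonyl in place of cyano. Compound 3 `CCOC(=O)c1ccc(-c2ccc(N(C)C)nn2)cc1` keeps the ethoxycarbonyl and instead carries dimethylamino in place of diethylamino (dimethylamino in place of diethylamino on an aromatic carbon). Among the measured compounds shown here, no measured step touches the amino group, so that large step gives no direct guide to this change. The expectation therefore stays anchored on compound 2 at 1500 nM. No shift beyond the scatter is expected in this assay, and the estimated change is a 1.2-fold higher number from compound 2 to compound 3 (0.08 log units; within the scatter). For compound 3 the expected value is 1800 nM, with an estimated range of 700 nM to 5000 nM.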

Compound 3, half-maximal inhibitory concentration: > 25000 nM
Compound 3: a limit, no number (the forecaster's own chance of this, stated with the estimate: 5%); middle value at least 13-fold (1.14 log units) away from the limit.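

Up to now the only measured step concerned the ethoxycarbonyl, so nothing showed how much the amino group matters. In this assay dimethylamino in place of diethylamino gives an at least 16-fold higher number from compound 2 to compound 3 (1.22 log units; beyond the scatter) and shows that this small trim, from 5 heavy atoms to 3, can matter as much as the earlier change of ethoxycarbonyl for cyano. The value of compound 3 is a limit of the assay and not a number, and it is the same limit seen before: the limit of > 25000 nM in this assay, at which 2 of the 3 values shown sit.

Within the data shown here, only two amino groups are compared here, so it remains open whether dipropylamino, with its longer chains, or a ring amine such as pyrrolidine or morpholine would give a lower number than compound 2. From the compounds shown here alone, it is also open whether a single ethyl on the nitrogen would keep any of the activity of compound 2.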